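Notes on the step from compound 2 to compound 3

The source may report more compounds than this note shows. Statements on the series, on what has been measured and on what is new or still open speak of the compounds shown alone.

Measured in an ADME assay on NHDF cells (Homo sapiens) for cytotoxicity, read by MTT assay, with a stated time of 72 h; on this read-out higher numbers stand for weaker inhibition and lower numbers for stronger inhibition:
- compound 1 `COc1cccc(/C=C2\CCC/C(=C\c3cccc(Cl)c3)C2=O)c1OC`: 21400 nM
- compound 2 `COc1ccc(/C=C2\CCC/C(=C\c3cccc(OC)c3OC)C2=O)cc1`: 43500 nM

Of the two measured compounds, compound 2 has the higher number, 43500 nM, and compound 1 has the lower, 21400 nM. The next structure is compound 3 `COc1cccc(/C=C2\CCC/C(=C\c3cccc(O)c3)C2=O)c1OC`, which differs from compound 2 as follows: 3-hydroxyphenyl in place of 4-methoxyphenyl on a double-bonded chain carbon bound to a double-bonded ring carbon. In words, it has 3-hydroxyphenyl in place of 4-methoxyphenyl on a double-bonded chain carbon bound to a double-bonded ring carbon.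

Within the data shown here, only one measured step bears on this place: a 2.0-fold higher number from compound 1 to compound 2 (0.31 log units; beyond the scatter), a modest one, with 4-methoxyphenyl in place of 3-chlorophenyl. Among the measured compounds shown here, it puts 4-methoxyphenyl on the higher side, but no measured compound carries 3-hydroxyphenyl, so the evidence is thin. Going by that single step, a small move toward a lower number is expected in this assay, and the estimated step is a 1.6-fold lower number from compound 2 to compound 3 (0.19 log units; within the scatter). Compound 3 is estimated at 28000 nM, with an expected range of 11000 nM to 60000 nM.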

Compound 3, half-maximal inhibitory concentration: 19300 nM
For compound 3 the middle estimate is 1.5-fold (0.16 log units) above the measured one; the range from low to high includes it.
By their numbers in this assay, from the lowest: compounds 3 and 1 (each within the scatter of the next); then compound 2.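

In this assay, the change to 3-hydroxyphenyl gives a 2.3-fold lower number from compound 2 to compound 3 (0.35 log units; beyond the scatter) and is the second step at this position to separate 4-methoxyphenyl from another group, so among the three compounds compound 2 stands apart from both others. Hydroxy in place of chloro on an aromatic carbon gives a 1.1-fold lower number from compound 1 to compound 3 (0.04 log units; within the scatter), which leaves 3-hydroxyphenyl and 3-chlorophenyl indistinguishable in this assay, even though 3-hydroxyphenyl carries a hydrogen-bond donor and 4-methoxyphenyl has none. Nothing at hand accounts for either step.

The three compounds do not settle whether the higher number of compound 2 goes with the methoxy group itself or with the place it occupies on the ring, since 4-methoxyphenyl differs from 3-hydroxyphenyl in both the group and its numbering. From the compounds shown here alone, it also remains open whether an amine or a carboxylic acid in place of the hydroxy on that aromatic carbon would stay level with compound 1 and compound 3 or move toward compound 2.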